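This account rests on a few compounds, and the source may have more. Where it says the series, first, only, none or still open, it means among the compounds named here.

Working notes on the series. All three measured compounds share one core and differ only in the aryl group on the aromatic nitrogen. In a functional assay on MCF7 cells (Homo sapiens) for inhibition, read by MTT assay, with a stated time of 72 h (a higher number here means a weaker inhibitor, a lower number a stronger inhibitor), compound 1 `N#Cc1c(Nc2cccc(C(F)(F)F)c2)nc(SCc2cn(Cc3ccccc3Cl)nn2)nc1-c1ccccc1` gives 12600 nM, the highest of the three numbers, though every gap here lies within the scatter. Compound 2 `N#Cc1c(Nc2cccc(Cl)c2)nc(SCc2cn(Cc3ccccc3Cl)nn2)nc1-c1ccccc1` gives 12000 nM and compound 3 `N#Cc1c(Nc2ccccc2F)nc(SCc2cn(Cc3ccccc3Cl)nn2)nc1-c1ccccc1` gives 8060 nM. Compound 4 `Cc1ccc(Nc2nc(SCc3cn(Cc4ccccc4Cl)nn3)nc(-c3ccccc3)c2C#N)cc1` is not yet measured; against compound 1 the change is 4-methylphenyl in place of 3-(trifluoromethyl)phenyl on a nitrogen on an aromatic ring. Among the measured compounds shown here, the steps that bear on it swap the same aryl group: a 1.1-fold lower number from compound 1 to compound 2 (0.02 log units; within the scatter) and a 1.6-fold lower number from compound 1 to compound 3 (0.19 log units; within the scatter), with a 1.5-fold lower number from compound 2 to compound 3 (0.17 log units; within the scatter) of the same kind. No step beyond the scatter is therefore expected from compound 1 to compound 4 in this assay, the estimate implying a 1.2-fold lower number from compound 1 to compound 4 (0.08 log units; within the scatter). Compound 4 is estimated at 10500 nM, with a range of 4500 nM to 25000 nM.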

Compound 4, half-maximal inhibitory concentration: 9420 nM
The estimate for compound 4 lay 1.1-fold (0.05 log units) above the measured number; the measured number falls inside the stated range.
By their numbers in this assay, from the lowest: compounds 3, 4, 2 and 1 (each within the scatter of the next).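

In this assay, among the compounds shown here, the 4-methylphenyl group, the one aryl group here without a halogen, gives a 1.3-fold lower number from compound 1 to compound 4 (0.13 log units; within the scatter), a 1.3-fold lower number from compound 2 to compound 4 (0.11 log units; within the scatter) and a 1.2-fold higher number from compound 3 to compound 4 (0.07 log units; within the scatter). Among these four compounds, a halogen on the aryl group on this nitrogen is therefore not required for a number in this range. Nothing available explains why these aryl groups read alike. From the compounds shown here alone, whether a carboxylic acid or an amine on this aryl ring would give a step beyond the scatter remains open. So does the effect of replacing the ring with a longer alkyl chain.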